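A few compounds are considered here, and "the series" means these few. Any claim that something is new, unique, unknown or untested is made for them only; others in the source may bear on it.

In a functional assay (muscle tissue) with Cavia porcellus as the target (a higher number here means that more compound is needed for the effect, a lower number that less compound is needed), the measured compounds stand as follows:

compound 1 `COC(=O)C1=C(C)N=C(C)/C(=C(\O)OC)C1c1cc(OC)c(OC)cc1OC` – 1000000 nM
compound 2 `COC(=O)C1=C(C)N=C(C)/C(=C(\O)OC)C1c1ccc(F)cc1` – 129 nM
compound 3 `COC(=O)C1=C(C)N=C(C)/C(=C(\O)OC)C1c1cccc(OC(C)=O)c1` – 6030 nM

Compound 2 gives the lowest number of the three; compound 3 is the nearest and sits well above it, compound 1 the furthest, both differences beyond the scatter. Compound 4 `COC(=O)C1=C(C)N=C(C)/C(=C(\O)OC)C1c1c(Cl)cccc1Cl` differs from compound 2 in one place: 2,6-dichlorophenyl in place of 4-fluorophenyl on a saturated ring carbon. For the measured compounds named here, no step between measured compounds changes only this part, so its size is not anchored by the series. Compound 2 gives 129 nM in this assay. Compound 4 is expected to stay near that or move somewhat lower, the step of a 2.2-fold lower number from compound 2 to compound 4 (0.33 log units; beyond the scatter) expected within the scatter or a little beyond it. Compound 4 is estimated at 60 nM, with a range from 10 nM to 500 nM.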

Compound 4, half-maximal effective concentration: 1.91 nM
Estimate against measurement, compound 4: 31-fold (1.50 log units) above, and the stated range ends above it.
By their numbers in this assay, from the lowest: compound 4; then compound 2; then compound 3; then compound 1.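

Changing the aryl group on the saturated ring carbon can move the number in this assay sharply: 2,6-dichlorophenyl in place of 4-fluorophenyl gives a 68-fold lower number from compound 2 to compound 4 (1.83 log units; beyond the scatter) in a single change. This position therefore has a strong effect on the read-out, and a halogen-bearing phenyl here can reach the low value of compound 4 at 1.91 nM and not merely stay near that of compound 2. Nothing at hand bears on why the step is this large.

The two chlorines and the loss of fluorine arrive together, so their separate shares stay unresolved. On these data alone, how a phenyl carrying an amine or a carboxylic acid would read in this assay also remains open.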